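This account rests on a few compounds, and the source may have more. Where it says the series, first, only, none or still open, it means among the compounds named here.

Measured so far:
compound 1 `CCN1CCN(c2nc(C)nc3c2nc(-c2ccccc2Cl)n3C)CC1` — 88%
compound 2 `COCCn1c(-c2ccccc2Cl)nc2c(N3CCN4C(=O)CCC4C3)nc(C)nc21` — 35%
compound 3 `Cc1nc(N2CCN(C)CC2)c2nc(-c3ccccc3C(F)(F)F)n(C3CCOCC3)c2n1` — 61%

These three were tested in an ADME assay (liver) for metabolic stability, with Liver microsome (Canis lupus familiaris) as the target, read by LC-MS, using microsomes, with a stated time of 30 min, tested at 4 uM; a lower number here means that less of the compound is left, a higher number that more of the compound is left. Compound 3 holds the second highest of the three numbers; its nearest neighbour is compound 2, a number beyond the scatter lower, and compound 1 stands beyond the scatter higher. Compound 4 `COc1ccc(-c2nc3c(N4CCN(C)CC4)nc(C)nc3n2C2CCOCC2)c(C)c1` is not yet measured. Compared with compound 3 it differs in one place: 4-methoxy-2-methylphenyl in place of 2-(trifluoromethyl)phenyl on an aromatic carbon. From the compounds shown here alone, no change of this kind has been measured, so the size of its effect is unknown. A moderate downward step in this assay is expected, a number 16 percentage points lower from compound 3 to compound 4 (beyond the scatter), somewhat beyond the scatter. Compound 4 is estimated at 45%, with a range from 20% to 75%.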

Compound 4, percent of the compound remaining: 41%
Compound 4: middle estimate off by 4 percentage points, on the high side, and the stated range covers the measured number.
By their numbers in this assay, from the lowest: compounds 2 and 4 (each within the scatter of the next); then compound 3; then compound 1.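

In this assay, putting 4-methoxy-2-methylphenyl in place of 2-(trifluoromethyl)phenyl gives a number 20 percentage points lower from compound 3 to compound 4 (beyond the scatter). Among the compounds shown here, the earlier compounds differ in several places at once, so this is the first sign that the aryl group at this position can, on its own, shift the number beyond the scatter. Nothing measured here explains the shift.

This swap changes several things at once, so the share of the methoxy, the methyl and the lost trifluoromethyl stays unresolved. From the compounds shown here alone, how a plain phenyl or a pyridine ring would behave at this position also remains open.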